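Nitro in Place of Methyl on the Shared Core

The source may hold more compounds than are shown below. What is called first, only, known or untested is meant among the compounds shown, and "the series" means these compounds.

Compound 1, `Cc1ccc2nc(NC(=O)/C=C/c3ccc(Cl)cc3)sc2c1`, gives 152 umol/kg in a functional assay on the whole organism (Hindlimb, strain albino) with Mus musculus as the target, in the maximal electroshock model, with a stated time of 0.5 h; on this read-out lower numbers stand for an effect already at smaller amounts and higher numbers for an effect only at larger amounts of compound.
Compound 2, `COc1ccc(/C=C/C(=O)Nc2nc3ccc(C)cc3s2)cc1`, gives 209 umol/kg in this assay.
Compound 3, `Cc1ccc2nc(NC(=O)/C=C/OC3=CC=C3)sc2c1`, gives 505 umol/kg in this assay.

Compound 1 holds the lowest number of the three, which on this read-out means an effect at the smallest amount. The two measured steps both alter the group at the far end of the chain. Methoxy in place of chloro on an aromatic carbon gives a 1.4-fold higher number from compound 1 to compound 2 (0.14 log units; within the scatter). Swapping the six-membered aromatic ring bearing chlorine for the four-membered ring gives a 3.3-fold higher number from compound 1 to compound 3 (0.52 log units; beyond the scatter).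

Compound 4, `O=C(/C=C/c1ccc(Cl)cc1)Nc1nc2ccc([N+](=O)[O-])cc2s1`, is not yet measured. Its change from compound 1 is nitro in place of methyl on an aromatic carbon. Among the compounds with values here, this alters the fused two-ring part of the shared core, a place no measured step touches, so neither step bears on it directly. With nothing measured at that position, the cautious expectation is no step beyond the scatter, though the uncertainty is wide. Compound 4 is therefore estimated at 190 umol/kg in this assay, with a range of 70 umol/kg to 500 umol/kg, meaning an expected step of a 1.3-fold higher number from compound 1 to compound 4 (0.10 log units; within the scatter).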

Compound 4, dose for half-maximal effect: 259 umol/kg
The estimate for compound 4 lay 1.4-fold (0.13 log units) below the measured number, within the range that was stated.
By their numbers in this assay, from the lowest: compounds 1, 2, 4 and 3 (each within the scatter of the next, the first and the last beyond it).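

Nitro in place of methyl, on an aromatic carbon of the six-membered aromatic ring in the fused part of the shared core, gives a 1.7-fold higher number from compound 1 to compound 4 (0.23 log units; within the scatter) in this assay. Within the data shown here, this is the first look at this place on the core, and it shows that going from methyl, with no hydrogen-bond acceptors, to the larger nitro, with two, does not move the number beyond the scatter in this pair. Of the three steps from compound 1, only a 3.3-fold higher number from compound 1 to compound 3 (0.52 log units; beyond the scatter) lies beyond the scatter, and that step alters the far end of the chain, not the core; nothing in the data explains why the number at the core stays so close.

A single pair cannot show whether this place is insensitive to change in general, and an amine, a carboxylic acid or a longer chain there could behave differently. Going by these compounds, it also remains open whether nitro would give a similar step when the chloro on the far ring is replaced by methoxy or when that ring gives way to the four-membered ring.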